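A few compounds are considered here, and "the series" means these few. Any claim that something is new, unique, unknown or untested is made for them only; others in the source may bear on it.

Of the compounds shown here, three built on one shared core have been measured in an assay on DDT1 cells (Cricetulus griseus) for binding affinity to adenosine receptor A1 (Homo sapiens), read by radioligand binding; a higher number here means a weaker inhibitor, a lower number a stronger inhibitor. Compound 1 `CCCC/N=C(\S)OC[C@H]1OC(n2cnc3c(NC4CCOC4)ncnc32)[C@H](O)[C@@H]1O` gives 157 nM, the lowest of the three numbers. Compound 2 `O[C@@H]1[C@@H](CO/C(S)=N/C2CCCCC2)OC(n2cnc3c(NC4CCOC4)ncnc32)[C@@H]1O` gives 253 nM, and the step of a 1.6-fold higher number from compound 1 to compound 2 (0.21 log units; within the scatter) stays within the scatter, so these two cannot be told apart. Compound 3 `O=C(NCc1ccccc1)OC[C@H]1OC(n2cnc3c(NC4CCOC4)ncnc32)[C@H](O)[C@@H]1O` gives 1830 nM; the steps of a 12-fold higher number from compound 1 to compound 3 (1.07 log units; beyond the scatter) and a 7.2-fold higher number from compound 2 to compound 3 (0.86 log units; beyond the scatter) both lie beyond the scatter.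

Compound 4 `CN(C)C(=O)OC[C@H]1OC(n2cnc3c(NC4CCOC4)ncnc32)[C@H](O)[C@@H]1O` has not yet been measured in this assay. It differs from compound 1 in one place: a group of 5 heavy atoms (3 carbon, 1 nitrogen, 1 oxygen; no ring) in place of a group of 7 heavy atoms (5 carbon, 1 nitrogen, 1 sulfur; no ring), on an oxygen on a saturated carbon. Among the compounds with values here, the group that leaves is the same group of 7 heavy atoms (5 carbon, 1 nitrogen, 1 sulfur; no ring) that left on the way to compound 3, and what enters again holds a nitrogen and an oxygen in place of the nitrogen and sulfur, so the step of a 12-fold higher number from compound 1 to compound 3 (1.07 log units; beyond the scatter) is the one measured step that speaks to this change. It was large and went toward a higher number, and a step of similar direction is expected here, though the entering group is smaller and carries no six-membered aromatic ring of carbon only.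

Compound 4 is therefore expected to give 1200 nM in this assay, with a range from 400 nM to 4000 nM. That expectation means a step of a 7.6-fold higher number from compound 1 to compound 4 (0.88 log units; beyond the scatter).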

Compound 4, inhibition constant: 238 nM
Estimate against measurement, compound 4: 5.0-fold (0.70 log units) above; measured number below the stated range.
By their numbers in this assay, from the lowest: compounds 1, 4 and 2 (each within the scatter of the next); then compound 3.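

In this assay the dimethylcarbamoyl group on this oxygen gives a step of a 1.5-fold higher number from compound 1 to compound 4 (0.18 log units; within the scatter) and a step of a 1.1-fold lower number from compound 2 to compound 4 (0.03 log units; within the scatter) so a carbonyl in this group is compatible with numbers that cannot be told apart across these two steps. The change from benzylamino to dimethylamino on the carbonyl carbon, a step of a 7.7-fold lower number from compound 3 to compound 4 (0.89 log units; beyond the scatter) shows that the high number of compound 3 goes with its benzylamino group and not with the carbonyl link alone, and among these four compounds only compound 3 stands apart. No measurement here explains why the benzylamino group goes with the higher number.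

The compounds shown leave open whether it is the benzene ring of that group or some other part of it that goes with the higher number, which a cyclohexylamino or phenylamino group on the carbonyl carbon would help to separate. A butylamino group on the carbonyl carbon would also compare the carbonyl directly with the sulfur-bearing carbon of compound 1 while keeping the butyl chain the same.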